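Methoxy removal on pyrazolyl enones in renal carcinoma cells

This account rests on a few compounds, and the source may have more. Where it says the series, first, only, none or still open, it means among the compounds named here.

Compound 1 `COc1ccc(-c2cc(/C=C/C(=O)c3ccc(N)cc3)[nH]n2)cc1`, compound 2 `COc1ccc(-c2cc(/C=C/C(=O)c3ccc(N)cc3)[nH]n2)cc1OC` and compound 3 `COc1cc(C(=O)/C=C/c2cc(-c3cc(OC)c(OC)c(OC)c3)n[nH]2)cc(OC)c1OC` are three measured members of the series. In a functional assay on A498 cells (Homo sapiens) for cytotoxicity, read by sulforhodamine B assay, with a stated time of 48 h, tested at 10 uM (a lower number here means a stronger effect, a higher number a weaker effect of the compound at the concentration tested), compound 1 gives -39%, compound 2 gives -16% and compound 3 gives -64%. Compound 3 stands lowest of the three numbers, and its steps to compound 1 and to compound 2 both lie beyond the scatter. The change from compound 2 to compound 1 is hydrogen in place of methoxy on an aromatic carbon and it produces a number 23 percentage points lower from compound 2 to compound 1 (beyond the scatter), a modest step beyond the scatter. The difference between the core of compound 2 and the core of compound 3 is not broken down here.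

Compound 4 `COc1ccc(-c2cc(/C=C/C(=O)c3cc(OC)c(OC)c(OC)c3)[nH]n2)cc1OC` has not been measured in this assay. It differs from compound 3 by hydrogen in place of methoxy on an aromatic carbon. This is the same kind of change as that from compound 2 to compound 1, not the same change: around the place, the aromatic carbon in compound 3 is also meta to a methoxy group, which is not so for the place in compound 2.

Among the measured compounds shown here, from compound 3 to compound 4 the step is expected to be a number 14 percentage points lower from compound 3 to compound 4 (beyond the scatter), set beside the earlier one because the only precedent is a number 23 percentage points lower from compound 2 to compound 1 (beyond the scatter), while compound 3 already stands at -64%, which leaves less room downward. Compound 4 is therefore estimated at -78%, between -98% and -55%.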

Compound 4, a percentage reported as activity, at one concentration (the size of the read-out at that concentration, not a potency): -28%
Estimate against measurement, compound 4: 50 percentage points below; measured number above the stated range.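

In this assay, the new step reads as a number a number 36 percentage points higher from compound 3 to compound 4 (beyond the scatter), so on the core of compound 3 hydrogen in place of methoxy on an aromatic carbon goes with a weaker effect at the concentration tested. Among the compounds shown here, the replacement therefore does not carry over from one core to another as a fixed step, and even its direction depends on the core: the same change on two cores in this assay, a number 23 percentage points lower (beyond the scatter) from compound 2 to compound 1 and a number 36 percentage points higher (beyond the scatter) from compound 3 to compound 4, 59 percentage points apart, beyond the scatter of two such steps With only two pairs, this does not show which difference between the cores decides the direction: the place in compound 3 is meta to a methoxy group, which is not so for the place in compound 2, but that feature cannot be separated from the other differences between the two cores, and no cause for the reversal can be assigned.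

The compounds shown leave open whether a third core would follow either pair, and whether the size of the step on each core is specific to this place on the ring. They also leave open how a hydroxy group, a fluorine atom or a longer chain such as ethoxy would read at this place on either core.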